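Sulfonyl group swaps: from compound 3 to compound 4

This account rests on a few compounds, and the source may have more. Where it says the series, first, only, none or still open, it means among the compounds named here.

Measured in an ADME assay (liver) for metabolic stability, with Liver microsome (Homo sapiens) as the target, read by LC-MS, using microsomes and NADPH, with a stated time of 5 min, at 37 degrees C; on this read-out higher numbers stand for fast clearance and lower numbers for slow clearance:
compound 1 `CCn1c([C@@H](C)NS(=O)(=O)c2ccccc2)nc2ccc(C(F)(F)F)cc21`: 14 mL.min-1.g-1
compound 2 `CCn1c([C@@H](C)NS(=O)(=O)c2c(F)cc(F)cc2F)nc2ccc(C(F)(F)F)cc21`: 19 mL.min-1.g-1
compound 3 `CCn1c([C@@H](C)NS(=O)(=O)c2cn(C)c(C)n2)nc2ccc(C(F)(F)F)cc21`: 43 mL.min-1.g-1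

Compound 3 carries the highest number of the three, at 43 mL.min-1.g-1. It stands beyond the scatter from both others, as shown by a 3.1-fold higher number from compound 1 to compound 3 (0.49 log units; beyond the scatter) and a 2.3-fold higher number from compound 2 to compound 3 (0.35 log units; beyond the scatter). The two aryl groups sit closer together, with a 1.4-fold higher number from compound 1 to compound 2 (0.13 log units; within the scatter).

Compound 4 `CCn1c([C@@H](C)NS(=O)(=O)c2cnc(C)n2C)nc2ccc(C(F)(F)F)cc21` has the same atoms as compound 3, joined differently: 1,2-dimethyl-1H-imidazol-5-yl in place of 1,2-dimethyl-1H-imidazol-4-yl on a sulfonyl sulfur. The swap is 1,2-dimethyl-1H-imidazol-5-yl in place of 1,2-dimethyl-1H-imidazol-4-yl on a sulfonyl sulfur. Among the measured compounds shown here, no measured step compares these two groups directly. The steps to compound 3 replace an aryl group with an imidazolyl group, so they are only a loose guide, and both are modest. A smaller change is expected for an exchange between two isomeric groups, with no direction favoured by the data. The expected result is a 1.1-fold lower number from compound 3 to compound 4 (0.05 log units; within the scatter), estimated to stay within the scatter. For compound 4 the estimated value is 38 mL.min-1.g-1, with an expected range of 17 mL.min-1.g-1 to 85 mL.min-1.g-1.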

Compound 4, intrinsic clearance in microsomes: 58 mL.min-1.g-1
Compound 4: the middle estimate sits 1.5-fold (0.18 log units) below what was measured, and the stated range covers the measured number.
By their numbers in this assay, from the lowest: compounds 1 and 2 (each within the scatter of the next); then compounds 3 and 4 (each within the scatter of the next).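

On the sulfonyl sulfur, the isomeric groups 1,2-dimethyl-1H-imidazol-5-yl and 1,2-dimethyl-1H-imidazol-4-yl are not told apart in this read-out of this assay (a 1.3-fold higher number from compound 3 to compound 4 (0.13 log units; within the scatter)). The gap from the aryl groups therefore does not rest on compound 3 alone: the 5-yl isomer also stands beyond the scatter from both (a 3.1-fold higher number from compound 2 to compound 4 (0.48 log units; beyond the scatter); a 4.1-fold higher number from compound 1 to compound 4 (0.62 log units; beyond the scatter)), and none of the four compounds goes against this split between imidazolyl and aryl groups. Nothing shown gives a reason for this gap.

Still open, from the compounds shown here alone, is whether the gap belongs to the imidazolyl ring or to its two methyl groups, which an unsubstituted imidazolyl group would test. A pyridinyl group or a dimethylamino group on the sulfonyl sulfur could show whether the gap extends beyond these groups.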